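Compound 3: methylamino for methylsulfanyl

The source may report more compounds than this note shows. Statements on the series, on what has been measured and on what is new or still open speak of the compounds shown alone.

Measured in a functional assay on HCT-116 cells (Homo sapiens), read by MTT assay, with a stated time of 72 h (on this read-out lower numbers stand for stronger inhibition and higher numbers for weaker inhibition), so far:
- compound 1 `CSc1ncnc2c1c(-c1ccoc1)cn2[C@@H]1O[C@H](CO)[C@@H](O)[C@H]1O` gives 100 nM
- compound 2 `CSc1ncnc2c1c(-c1ccccc1)cn2[C@@H]1O[C@H](CO)[C@@H](O)[C@H]1O` gives > 20000 nM as a limit of the assay

For the measured compounds named here, compound 1 holds the only true number so far, at 100 nM in this assay. Compound 2 gives > 20000 nM, which is a limit and not a number. That leaves no numerical spread against which to place compound 1.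

Compound 3 `CNc1ncnc2c1c(-c1ccoc1)cn2[C@@H]1O[C@H](CO)[C@@H](O)[C@H]1O` is next. The change from compound 1 is methylamino in place of methylsulfanyl on an aromatic carbon, and it keeps the furan-3-yl group of compound 1.

Going by the values given here, the one measured step is an at least 200-fold higher number from compound 1 to compound 2 (2.30 log units; beyond the scatter), with phenyl in place of furan-3-yl on an aromatic carbon. That step is large, but it lies at another place on the shared core, so it gives no size for the present change. Among the compounds with values here, no measured step touches the methylsulfanyl group. The anchor is therefore compound 1 at 100 nM, and no step beyond the scatter is expected in this assay, with only a slight lean towards a higher number.

The expected step is a 1.5-fold higher number from compound 1 to compound 3 (0.18 log units; within the scatter), an estimate with wide uncertainty.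

For compound 3 the estimated value is 150 nM, with an expected range from 30 nM to 1000 nM.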

Compound 3, half-maximal inhibitory concentration: > 20000 nM
Compound 3 ended at the assay's limit; the forecaster's own chance of this, stated with the estimate: 5%; middle value at least 130-fold (2.12 log units) from the limit.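

In this assay, methylamino in place of methylsulfanyl, with the furan-3-yl group kept, gives an at least 200-fold higher number from compound 1 to compound 3 (2.30 log units; beyond the scatter). For the compounds shown here, the methylsulfanyl position, which no earlier step touched, is therefore as unforgiving in this assay as the furan-3-yl position, and a change of just the sulfur to a nitrogen bearing a hydrogen-bond donor is enough to lose the number held by compound 1. The true size of this step cannot be read, and it cannot be ranked against the step to compound 2, as both end at the same limit and not at a number: the limit of > 20000 nM in this assay, at which 2 of the 3 values shown sit.

From the compounds shown here alone, only compound 1 carries a true number, so it remains open whether a methoxy group, a plain amine or a longer chain such as ethylsulfanyl at this position would stay close to compound 1 or fall away as methylamino does. It is also open whether methylsulfanyl is needed with aromatic groups other than furan-3-yl, since the series shown offers no second pair that differs at this position alone.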